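Compound 3 to compound 4: one change on a ring

The source may hold more compounds than are shown below. What is called first, only, known or untested is meant among the compounds shown, and "the series" means these compounds.

Measured in a functional assay on A549 cells (Homo sapiens) for cytotoxicity, read by sulforhodamine B assay, with a stated time of 48 h; a lower number here means a stronger inhibitor, a higher number a weaker inhibitor:
- compound 1 `COc1ccc(/C=C/C(=O)c2ccc(N)c(-c3ccc(F)cc3)c2)cc1O`: 940 nM
- compound 2 `COc1ccc(/C=C/C(=O)c2cccc(-c3ccc(F)cc3)c2)cc1`: 11200 nM
- compound 3 `COc1cc(/C=C/C(=O)c2ccc(N)c(-c3ccc(F)cc3)c2)ccc1O`: 12200 nM

Compound 3 sits within the usual scatter of compound 2, and both numbers lie far above that of compound 1. Going on to compound 4 `COc1ccc(/C=C/C(=O)c2ccc(N)c(-c3ccc(F)cc3)c2)cc1` makes one change: 4-methoxyphenyl in place of 4-hydroxy-3-methoxyphenyl on a double-bonded chain carbon bound to a double-bonded chain carbon. Among the measured compounds shown here, the only measured step on this group is large: a 13-fold higher number from compound 1 to compound 3 (1.11 log units; beyond the scatter). So a change here can matter, but that step swaps different groups. Compound 2 also carries 4-methoxyphenyl and gives 11200 nM, although its core differs. A modest drop is therefore expected in this assay, with the estimated step being a 2.4-fold lower number from compound 3 to compound 4 (0.39 log units; beyond the scatter). Compound 4 is estimated at 5000 nM, with an expected range of 1500 nM to 15000 nM.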

Compound 4, half-maximal inhibitory concentration: 4310 nM
Compound 4: the middle estimate sits 1.2-fold (0.06 log units) above what was measured, and the stated range covers the measured number.
By their numbers in this assay, from the lowest: compound 1; then compound 4; then compounds 2 and 3 (each within the scatter of the next).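

With 4-methoxyphenyl as the reference, this ring can now be read in both directions: replacing 4-hydroxy-3-methoxyphenyl gives (a 2.8-fold lower number from compound 3 to compound 4 (0.45 log units; beyond the scatter)), while hydrogen in place of hydroxy gives (a 4.6-fold higher number from compound 1 to compound 4 (0.66 log units; beyond the scatter)). The hydroxy and methoxy arrangements of compound 1 and compound 3 therefore fall on opposite sides of compound 4. Amino in place of hydrogen on an aromatic carbon also counts (a 2.6-fold lower number from compound 2 to compound 4 (0.41 log units; beyond the scatter)), and no measurement at hand explains any of these shifts.

Still open, on these data alone, is whether an ethoxy or chloro group on this ring would follow compound 1 or compound 3. Also open, as far as these compounds go, is whether a dimethylamino group or an amide in place of amino would keep the lower number.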